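This account rests on a few compounds, and the source may have more. Where it says the series, first, only, none or still open, it means among the compounds named here.

Working notes on the series. Compound 1 `NC1=NC2(CCSCC2)N(OCCCOc2ccc(Br)cc2)C(N)=N1` has "not determined" (no result reported) in an assay on isolated protein for inhibition of Dihydrofolate reductase (Homo sapiens), read by spectrophotometry, using NADPH, with stated times of 5 s and 6 min, tested at 50 uM (a higher number here means a stronger effect of the compound at the concentration tested, a lower number a weaker effect), that is, no result reported. Within the data shown here, compound 2 `NC1=NC2(CCSCC2)N(OCCCOc2cc(Cl)c(Cl)cc2Cl)C(N)=N1` gives 94.4% in this assay; this is the only number in the set so far, with compound 1 standing beside it without a figure, so no step between measured compounds can be drawn and compound 2 is simply the one reading on hand, close to the top of the scale.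

Compound 3 `NC1=NC2(CCSCC2)N(OCCCOc2ccccc2Cl)C(N)=N1` is the next member to be measured in this assay. It differs from compound 2 as follows: 2-chlorophenyl in place of 2,4,5-trichlorophenyl on an oxygen on a saturated carbon.

Among the measured compounds shown here, with no measured step, the expectation rests only on the reading of compound 2 and on the exchange of 2,4,5-trichlorophenyl for 2-chlorophenyl. The step is expected to be a number 14.4 percentage points lower from compound 2 to compound 3 (beyond the scatter), a modest fall that may or may not exceed the scatter, because compound 2 already stands high with 94.4% and leaves little room upward. Compound 3 is accordingly expected to give 80%, with a plausible range from 55% to 97%.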

Compound 3, a percentage reported as inhibition, at one concentration (the size of the read-out at that concentration, not a potency): 89.6%
Compound 3: middle estimate off by 9.6 percentage points, on the low side, within the range that was stated.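

In this assay, among these compounds, the exchange of 2,4,5-trichlorophenyl for 2-chlorophenyl on an oxygen on a saturated carbon gives a number 4.8 percentage points lower from compound 2 to compound 3 (within the scatter), the first measured step at this position. It shows that this position tolerates the change in chlorine count shown here without a reading separable from that of the trichlorinated group, although the read-out is the size of an effect at one concentration and not a potency, so a difference in potency could remain hidden. No available evidence explains this outcome.

The compounds shown leave open whether an unsubstituted phenyl or a phenyl ring bearing an amine or a carboxylic acid would give a comparable reading. They also leave open how a longer chain on the oxygen of the shared core would read.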